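The source may hold more compounds than are shown below. What is called first, only, known or untested is meant among the compounds shown, and "the series" means these compounds.

Three compounds built on one shared core were run in an ADME assay on Caco-2 cells (Homo sapiens) for permeability, read by LC-MS, in the apical to basolateral direction, with a stated time of 60 min, at pH 6.5; on this read-out lower numbers stand for lower permeability and higher numbers for higher permeability. Compound 2 `CC(C)(C)[C@@H](O)C(=O)N1[C@@H]2C[C@@H]2C[C@H]1C(=O)NCc1cc(Cl)ccc1-n1cnnn1` gives 34 10^-6 cm/s. Compound 1 `CC(C)(C)C[C@@H](O)C(=O)N1[C@@H]2C[C@@H]2C[C@H]1C(=O)NCc1cc(Cl)ccc1-n1cnnn1` carries neopentyl in place of tert-butyl on a saturated chain carbon bound to a carbonyl carbon and an oxygen on a saturated carbon; in this assay compound 1 gives 24 10^-6 cm/s, and the step of a 1.4-fold lower number from compound 2 to compound 1 (0.15 log units; within the scatter). Compound 3 `CC(C)(C)[C@@H](O)C(=O)N1[C@H](C(=O)NCc2cc(Cl)ccc2-n2cnnn2)C[C@@H]2C[C@@H]21` shows (the two compounds have the same atoms and bonds and differ only in configuration as drawn: 2 of 4 stereo elements differ; a stereocentre at a saturated ring carbon is drawn R in compound 2 and S in compound 3; a stereocentre at a saturated ring carbon is drawn R in compound 2 and S in compound 3); in this assay compound 3 gives 16 10^-6 cm/s, a step of a 2.1-fold lower number from compound 2 to compound 3 (0.33 log units; beyond the scatter), which stands with the fact that compounds 2 and 3 differ only in the configuration as drawn. Compound 4 `CC(C)(C)C[C@@H](O)C(=O)N1[C@H](C(=O)NCc2cc(Cl)ccc2-n2cnnn2)C[C@@H]2C[C@@H]21` has no number yet in this assay; it differs from compound 3 by neopentyl in place of tert-butyl on a saturated chain carbon bound to a carbonyl carbon and an oxygen on a saturated carbon, the same change as from compound 2 to compound 1, at the same place word for word. Because the earlier step of a 1.4-fold lower number from compound 2 to compound 1 (0.15 log units; within the scatter) stayed within the scatter, compound 4 is expected to show a step of a 1.2-fold lower number from compound 3 to compound 4 (0.09 log units; within the scatter). Compound 4 is estimated at 13 10^-6 cm/s, between 7 10^-6 cm/s and 26 10^-6 cm/s.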

Compound 4, apparent permeability: 25 10^-6 cm/s
Compound 4: middle estimate off by 1.9-fold (0.28 log units), on the low side; measured number inside the range.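

In this assay the new step is a 1.6-fold higher number from compound 3 to compound 4 (0.19 log units; within the scatter), and the two compounds with neopentyl, which differ only in configuration as drawn, stand at a 1.0-fold higher number from compound 1 to compound 4 (0.02 log units; within the scatter). Set beside the earlier step, neopentyl in place of tert-butyl carries from one core to the other with no difference that can be told from the scatter: the same change on two cores in this assay, a 1.4-fold lower number (0.15 log units; within the scatter) from compound 2 to compound 1 and a 1.6-fold higher number (0.19 log units; within the scatter) from compound 3 to compound 4, 2.2-fold (0.35 log units) apart, within the scatter of two such steps. Each step stays within the scatter on its own, however, so the two pairs show neither a real effect of the change on either core nor a shared direction.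

The compounds shown leave open how a longer chain, an amine or a carboxylic acid at the same place would read on either core.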